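The source may report more compounds than this note shows. Statements on the series, on what has been measured and on what is new or still open speak of the compounds shown alone.

Measured so far:
- compound 1 `COc1ccc(C(c2ccc(OC(C)CN(C)C)cc2)c2cccc3ccccc23)c(OC)c1OC`, in a functional assay on HCT-116 cells (Homo sapiens) for inhibition, read by sulforhodamine B assay, with a stated time of 48 h (a lower number here means a stronger inhibitor, a higher number a weaker inhibitor), compound 1 gives 8410 nM.
- compound 2 `COc1ccc(C(OCc2ccccc2)c2cccc3ccccc23)c(OC)c1OC`, for which compound 2 reaches only a limit, > 20000 nM, in this assay.
- compound 3 `COc1ccc(C(c2ccc(O)cc2)c2cccc3ccccc23)c(OC)c1OC`, which in this assay gives 16000 nM.

Compound 3 has the higher of the two numbers, with compound 1 nearest: a 1.9-fold higher number from compound 1 to compound 3 (0.28 log units; within the scatter). One of the three values is a limit, (the limit of > 20000 nM in this assay, at which 1 of the 3 values shown sits). Compound 4 `COc1ccc(C(OCc2ccc(C)cc2)c2cccc3ccccc23)c(OC)c1OC` differs from compound 3 by (4-methylbenzyl)oxy in place of 4-hydroxyphenyl on a saturated chain carbon bound to two aromatic carbons. The step that bears on this is the reverse of an at least 1.2-fold lower number from compound 2 to compound 3 (0.09 log units; that floor lies within the scatter), so the change towards a benzyloxy-type group is expected to raise the number, probably back to a limit. Compound 4 is therefore estimated at 25000 nM, between 12000 nM and 60000 nM, an expected step of a 1.6-fold higher number from compound 3 to compound 4 (0.19 log units; within the scatter).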

Compound 4, half-maximal inhibitory concentration: > 20000 nM
Compound 4 was reported as a limit; the forecaster's own chance of this, stated with the estimate: 60%; the middle value does not contradict the limit.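

Compound 4 reaches only a limit in this assay, the same limit as compound 2: the limit of > 20000 nM in this assay, at which 2 of the 4 values shown sit. On these data alone, the change on this saturated chain carbon gives an at least 1.2-fold higher number from compound 3 to compound 4 (0.09 log units; that floor lies within the scatter), so its true size remains unknown. Adding methyl in place of hydrogen on an aromatic carbon, the one difference between compound 2 and compound 4, cannot be read between two limits.

The compounds shown leave open whether any benzyloxy-type group here differs from 4-hydroxyphenyl by more than the scatter. They also leave open what a carboxylic acid in place of that methyl would give.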